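This account rests on a few compounds, and the source may have more. Where it says the series, first, only, none or still open, it means among the compounds named here.

Compound 1 `C#Cc1cccc(Nc2ncnc3cc(OC)c(OCCCCC(=O)Nc4ccc(S(N)(=O)=O)cc4)cc23)c1` gives 7720 nM in a functional assay on A549 cells (Homo sapiens) for antiproliferative activity, read by MTT assay, with a stated time of 72 h; a higher number here means a weaker inhibitor, a lower number a stronger inhibitor.
Compound 2 `COc1cc2ncnc(Nc3cccc(F)c3)c2cc1OCCCCC(=O)Nc1ccc(S(N)(=O)=O)cc1` reaches only a limit of the assay, > 40000 nM.
Compound 3 `COc1cc2ncnc(Nc3ccc(F)cc3)c2cc1OCCCCC(=O)Nc1ccc(S(N)(=O)=O)cc1` likewise reaches only a limit, > 40000 nM.

Compound 3 thus stands at the edge of what this assay can report, and the step that the two limits leave unreadable from compound 2 to compound 3 cannot be sized because both ends sit at the limit of > 40000 nM in this assay, at which 2 of the 3 values shown sit.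

Compound 4 `COc1cc2ncnc(Nc3ccccc3)c2cc1OCCCCC(=O)Nc1ccc(S(N)(=O)=O)cc1` differs from compound 3 by hydrogen in place of fluoro on an aromatic carbon. Among the compounds with values here, no measured step swaps a fluoro for a hydrogen. The nearest guides are an at least 5.1-fold higher number from compound 1 to compound 2 (0.71 log units; beyond the scatter) and an at least 5.1-fold higher number from compound 1 to compound 3 (0.71 log units; beyond the scatter), which show that the fluorophenyl groups on the nitrogen on an aromatic ring push the number beyond the reportable range, but they say nothing about whether removing the fluoro moves it again. Since compound 3 is already at a limit, the expected step of a number no higher from compound 3 to compound 4 (the limit leaves the size open) is small and largely unreadable. Compound 4 is estimated at 40000 nM, with a range from 15000 nM to 100000 nM, and is expected most likely to be reported only as a limit once more.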

Compound 4, half-maximal inhibitory concentration: > 40000 nM
Compound 4 gave a limit, no number; the forecaster's own chance of this, stated with the estimate: 65%; the middle value lies on the limit itself.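

Removing the fluoro altogether does not bring back measurable activity in this assay, so the loss seen with compound 2 and compound 3 does not depend on fluoro being on that ring. Among these compounds, only compound 1 carries the ethynyl and only compound 1 gives a number, and replacing that group with hydrogen gives an at least 5.1-fold higher number from compound 1 to compound 4 (0.71 log units; beyond the scatter), the same kind of step as replacing it with fluoro. The steps among compound 2, compound 3 and compound 4 cannot be read, since each of these compounds gives only a limit: the limit of > 40000 nM in this assay, at which 3 of the 4 values shown sit.

Going by these compounds, whether these three compounds truly differ from one another therefore stays open. Also open, on these data alone, is whether ethynyl is special or whether another group on the same ring, such as a nitrile, chloro or methyl, would also give a measurable value.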